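A few compounds are considered here, and "the series" means these few. Any claim that something is new, unique, unknown or untested is made for them only; others in the source may bear on it.

Measured compounds in a functional assay on KB 3-1 cells (Homo sapiens) for cytotoxicity, read by MTT assay, with a stated time of 68 h; on this read-out lower numbers stand for stronger inhibition and higher numbers for weaker inhibition:
Compound 1, `O=C(Nc1cccc(-c2ccoc2)c1)C(Cl)Cl`, gives > 50000 nM, a limit of the assay.
Compound 2, `O=C(Nc1cccc(-c2cccc(F)c2)c1)C(Cl)Cl`, gives > 50000 nM, a limit of the assay.
Compound 3, `O=C(Nc1cccc(-c2nccs2)c1)C(Cl)Cl`, gives > 50000 nM, a limit of the assay.

Compound 3 thus stands at a limit in this assay, and no number is known for it; the two further values shown are limits as well, so nothing places compound 3 above or below its neighbours. For the measured compounds named here, the one step among the measured compounds, a step that the two limits leave unreadable from compound 1 to compound 3, cannot be read either, since both of its ends sit at the limit. Going by the values given here, the only evidence available is the limit of > 50000 nM in this assay, at which 3 of the 3 values shown sit.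

The unmeasured compound 4, `O=C(Nc1cccc(-c2cccs2)c1)C(Cl)Cl`, differs from compound 3 in one place: thiophen-2-yl in place of 1,3-thiazol-2-yl on an aromatic carbon. Among the compounds with values here, no measured step bears on this change, because every value shown is a limit, and the exchange of one five-membered aromatic ring for another has not moved any compound off the limit so far. Compound 4 is therefore expected to remain near the limit, with a step of a number no higher from compound 3 to compound 4 (the limit leaves the size open) that is estimated as none beyond the scatter. For compound 4 the estimate in this assay is 50000 nM, within a range from 15000 nM to 100000 nM, with a high chance that only a limit is reported.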

Compound 4, half-maximal inhibitory concentration: > 50000 nM
Compound 4 was reported as a limit; the forecaster's own chance of this, stated with the estimate: 80%; the middle value sits exactly at the limit.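

In this assay compound 4 gives > 50000 nM, a limit of the assay. Its steps from compound 1 and compound 3 cannot be read, as all values sit at one limit: the limit of > 50000 nM in this assay, at which 4 of the 4 values shown sit.

The compounds shown leave open how any of the four ranks against the others in this assay, and which change to the shared core would give a readable number.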